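Swapping methyl for sulfanyl in a spleen activation series

The compounds below may be only part of what the source reports. "The series", "measured", "known", "first", "only" and "open" are said of these compounds alone.

Of the compounds shown here, three built on one shared fused core have been measured in a functional assay (spleen, spleen) for activation, with Mus musculus as the target; a higher number here means that more compound is needed for the effect, a lower number that less compound is needed. Compound 1 `CCCCOc1nc(N)c2[nH]c(=O)n(Cc3ccccc3)c2n1` gives 0.001 uM. Compound 2 `CCCNc1nc(N)c2nc(O)n(Cc3ccccc3)c2n1` gives 0.1 uM. Compound 3 `Cc1nc(N)c2nc(O)n(Cc3ccccc3)c2n1` gives 1 uM, the highest of the three numbers, so it needs the most compound for the effect; compound 2 is its nearest neighbour and compound 1 its furthest.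

Among the compounds with values here, only one measured step touches compound 3: a 10-fold higher number from compound 2 to compound 3 (1.00 log units; beyond the scatter). Compounds 1 and 3 differ in more than one place, so their values can only be compared, not attributed to a single change.

Compound 4 `Nc1nc(S)nc2c1nc(O)n2Cc1ccccc1` is the next step from compound 3 and differs from it as follows: sulfanyl in place of methyl on an aromatic carbon. The step from compound 2 to compound 3 bears on this, since it also removed a substituent carrying a hydrogen-bond donor and acceptor at the same place and raised the number modestly. Returning such a group, here a small one, is expected to move the number back down by a modest amount, though the sulfanyl group has no precedent in the measured set, so the expectation is loose.

Compound 4 is therefore estimated to give 0.3 uM, expected to lie between 0.03 uM and 3 uM. That expectation corresponds to a 3.3-fold lower number from compound 3 to compound 4 (0.52 log units; beyond the scatter).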

Compound 4, minimum effective concentration: 10 uM
Beside the measured number, compound 4's estimate is 33-fold (1.52 log units) below it; measured number outside the range, above it.
By their numbers in this assay, from the lowest: compound 1; then compound 2; then compound 3; then compound 4.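

Sulfanyl in place of methyl on this aromatic carbon gives a 10-fold higher number from compound 3 to compound 4 (1.00 log units; beyond the scatter) in this assay and so does not take the number back towards that of compound 2. Sulfanyl carries one hydrogen-bond donor and one hydrogen-bond acceptor where methyl carries none, so the presence of these alone does not bring the number down in this pair. Sulfanyl in place of propylamino gives a 100-fold higher number from compound 2 to compound 4 (2.00 log units; beyond the scatter) and is the largest of the steps at this position, which ranks the three groups from propylamino through methyl to sulfanyl as the number rises, and even this exchange of one heavy atom for another moves the number beyond the usual scatter.

On these data alone, whether a plain amine, a methoxy group or a longer sulfur-linked chain such as butylsulfanyl on this carbon would sit closer to compound 2 or to compound 4 remains open. Why sulfanyl raises the number also stays unexplained, as nothing available here speaks to the reason.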